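Fluorine on the phenyl ring of a prenylated flavanone scaffold

The source may report more compounds than this note shows. Statements on the series, on what has been measured and on what is new or still open speak of the compounds shown alone.

Compound 1 `CC(C)=CCOc1ccc2c(c1)OC(c1ccccc1)CC2=O`: 6070 nM
Compound 2 `CC(C)=CCOc1ccc2c(c1)OC(c1ccc(F)cc1)CC2=O`: 7320 nM
Compound 3 `CC(C)=CCOc1cc(O)c2c(c1)OC(c1ccccc1)CC2=O`: 7320 nM

In a functional assay (a higher number here means a weaker inhibitor, a lower number a stronger inhibitor), compound 1 gives 6070 nM. Compound 2 differs from it by fluoro in place of hydrogen on an aromatic carbon, and this gave a 1.2-fold higher number from compound 1 to compound 2 (0.08 log units; within the scatter). Compound 3 differs from compound 1 by hydroxy in place of hydrogen on an aromatic carbon, with a 1.2-fold higher number from compound 1 to compound 3 (0.08 log units; within the scatter). Compound 4 `CC(C)=CCOc1cc(O)c2c(c1)OC(c1ccccc1F)CC2=O` has not been measured; it differs from compound 3 by fluoro in place of hydrogen on an aromatic carbon. This is the same kind of change as that from compound 1 to compound 2, though not the same: there the fluoro stood para to a large group, here it stands ortho to a large group. Because a 1.2-fold higher number from compound 1 to compound 2 (0.08 log units; within the scatter) lay within the scatter, the step of a 1.1-fold higher number from compound 3 to compound 4 (0.04 log units; within the scatter) is expected to be small as well. Compound 4 is therefore estimated at 8000 nM, between 4000 nM and 16000 nM.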

Compound 4, half-maximal inhibitory concentration: 5300 nM
Compound 4: middle estimate off by 1.5-fold (0.18 log units), on the high side; measured number inside the range.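

In this assay, fluoro in place of hydrogen, here ortho to a large group, gave a 1.4-fold lower number from compound 3 to compound 4 (0.14 log units; within the scatter). Set beside the earlier step on the other core, the change gives no sign of depending on the core: the same change on two cores in this assay, a 1.2-fold higher number (0.08 log units; within the scatter) from compound 1 to compound 2 and a 1.4-fold lower number (0.14 log units; within the scatter) from compound 3 to compound 4, 1.7-fold (0.22 log units) apart, within the scatter of two such steps. Going by these compounds alone, this does not show that the change carries over unchanged across the series, since only two pairs are at hand, the fluoro stands at a different place in each, and steps this small could conceal a modest real difference.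

The compounds shown leave open whether another group on the phenyl ring, such as an amine or a carboxylic acid, would move the number beyond the scatter. They also leave open what a longer chain in place of the prenyl chain would do.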